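The source may hold more compounds than are shown below. What is called first, only, known or untested is meant among the compounds shown, and "the series" means these compounds.

Measured so far in a functional assay on MCF7 cells (Homo sapiens) for inhibition, read by MTT assay, with a stated time of 24 h (a lower number here means a stronger inhibitor of growth, a higher number a weaker inhibitor of growth), for this series
- compound 1 `COc1cccc(C(=O)n2c(-c3cn(C)c4ccccc34)nc3ccccc32)c1` gives 15700 nM
- compound 2 `COc1cccc(C(=O)n2c(-c3cn(C)c4ccc(OC)cc34)nc3ccccc32)c1` gives 14600 nM
- compound 3 `COc1ccc2c(c1)c(-c1nc3ccccc3n1C(=O)c1cc(OC)c(OC)c(OC)c1)cn2C` gives 5100 nM

Compound 2 at 14600 nM lies within the scatter of compound 1 at 15700 nM and so sits at the upper end of the numbers, together with compound 1. Compound 3 at 5100 nM gives a lower number than either, beyond the scatter.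

Next is compound 4 `COc1ccc2c(c1)c(-c1nc3ccccc3n1C(=O)c1cccc(Br)c1)cn2C` and the difference from compound 2 is bromo in place of methoxy on an aromatic carbon. This is bromo in place of methoxy on an aromatic carbon, so 3-methoxyphenyl becomes 3-bromophenyl.

Within the data shown here, only one measured step exists, a 1.1-fold lower number from compound 1 to compound 2 (0.03 log units; within the scatter), and it lies within the scatter. That step adds a methoxy at another place in the molecule, so it bears only loosely on this change. Among the measured compounds shown here, no measured pair exchanges methoxy for bromo, and the data give no firm direction. The value of compound 3 at 5100 nM shows that a number beyond the scatter from compound 2 is possible among compounds differing on this same ring, so the range is kept wide.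

The estimated step is a 1.3-fold lower number from compound 2 to compound 4 (0.12 log units; within the scatter) and no step beyond the scatter is expected. For compound 4 the expected value is 11000 nM with an estimated range from 4500 nM to 25000 nM.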

Compound 4, concentration for 50% growth inhibition: 52700 nM
Beside the measured number, compound 4's estimate is 4.8-fold (0.68 log units) below it; the measured number lies above the stated range.
By their numbers in this assay, from the lowest: compound 3; then compounds 2 and 1 (each within the scatter of the next); then compound 4.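

In this assay, among these compounds, the exchange on the 3-methoxyphenyl ring gives a 3.6-fold higher number from compound 2 to compound 4 (0.56 log units; beyond the scatter), the first change between two compounds differing in one place that lies beyond the scatter. Among the compounds shown here, the only earlier such step, a 1.1-fold lower number from compound 1 to compound 2 (0.03 log units; within the scatter), lay within the scatter and was made at another place in the molecule, so it gave no sign that the number could move this far. This position on the ring therefore responds to the replacement of methoxy with bromo, and the change goes towards a weaker inhibitor of growth, though this rests on a single pair, and no measured evidence accounts for the shift.

As far as these compounds go, whether the higher number follows from the arrival of bromo or from the departure of methoxy stays open, and one pair cannot separate the two. An unsubstituted phenyl, or a chloro, an amine or a carboxylic acid on the same aromatic carbon, would show how the number at this position moves with groups other than these two.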